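A few compounds are considered here, and "the series" means these few. Any claim that something is new, unique, unknown or untested is made for them only; others in the source may bear on it.

Measured compounds in a functional assay on A-431 cells (Homo sapiens) for cytotoxicity, read by MTT assay, with a stated time of 48 h; a higher number here means a weaker inhibitor, a lower number a stronger inhibitor:
- compound 1 `CCCCCCCCNC(=O)[C@@H](NC(=O)c1cc2ccccc2o1)[C@@H](C)O` gives 52700 nM
- compound 2 `CCCCCCCCNC(=O)[C@@H](NC(=O)/C=C/c1ccccc1)[C@@H](C)O` gives 36000 nM
- compound 3 `C/C=C/C=C/C(=O)N[C@H](C(=O)NCCCCCCCC)[C@@H](C)O` gives 58200 nM

Compound 2 has the lowest of the three numbers, but its neighbours sit close: a 1.5-fold lower number from compound 1 to compound 2 (0.17 log units; within the scatter) and a 1.6-fold higher number from compound 2 to compound 3 (0.21 log units; within the scatter) are both within the scatter, as is a 1.1-fold higher number from compound 1 to compound 3 (0.04 log units; within the scatter). The three acyl variants on the shared core of compound 2 are therefore not separable in this assay.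

Compound 4 `CCCCCCCCCCCCNC(=O)[C@@H](NC(=O)/C=C/c1ccccc1)[C@@H](C)O` is the unmeasured analogue. The change from compound 2 to compound 4 is butyl in place of hydrogen on a saturated chain carbon, eight bonds along the chain from an amide-type nitrogen. Among the compounds with values here, all three measured steps concern the acyl side of the core; none touches the alkyl amide chain, so no measured step bears on this change. Given that the acyl variations produced steps within the scatter, the working expectation is that compound 4 stays near compound 2, with a step of a 1.2-fold lower number from compound 2 to compound 4 (0.08 log units; within the scatter) that is expected to be within the scatter, with no direction assigned. Compound 4 is accordingly estimated at 30000 nM in this assay, with a range from 9000 nM to 100000 nM that reflects the lack of any measured chain-length comparison.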

Compound 4, half-maximal inhibitory concentration: > 200000 nM
Compound 4 gave a limit, no number; the forecaster's own chance of this, stated with the estimate: 15%; middle value at least 6.6-fold (0.82 log units) from the limit.
By their numbers in this assay, from the lowest: compounds 2, 1 and 3 (each within the scatter of the next). At a limit, above all of these: compound 4.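

In this assay, butyl in place of hydrogen on a saturated chain carbon, eight bonds along the chain from an amide-type nitrogen, gives an at least 5.5-fold higher number from compound 2 to compound 4 (0.74 log units; beyond the scatter). The earlier steps all lay on the acyl side of the core and all stayed within the scatter, so this is the first change shown that separates two compounds in this assay, and it places the alkyl amide chain, not the acyl group, as the part of the series to which the read-out responds, with the longer chain on the weaker side. The reading for compound 4 is a limit and not a number, so the step gives a direction and a minimum size, with its full size unknown: the limit of > 200000 nM in this assay, at which 1 of the 4 values shown sits.

Still open, going by these compounds, is how the read-out behaves along the chain: whether methyl or ethyl in place of hydrogen at the same place already gives a step beyond the scatter, and whether a chain ending in an amine or a carboxylic acid behaves like butyl. Also open, on these data alone, is whether the same butyl change gives a similar step on the 1-benzofuran-2-yl or penta-1,3-dien-1-yl acyl variants.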